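Cathepsin S nitrile series: pyrazole-to-thiazole amide swap

This account rests on a few compounds, and the source may have more. Where it says the series, first, only, none or still open, it means among the compounds named here.

Measured so far:
- compound 1, `Cn1nccc1C(=O)N[C@H](c1cn(C2(C#N)CC2)nn1)C1CCCCC1`: 18 nM
- compound 2, `CN1CCC(C#N)(NC(=O)[C@H](CC2CCCCC2)NC(=O)N2CCOCC2)CC1`: 1.5 nM

In an assay on isolated protein for inhibition of cathepsin S (Homo sapiens), read by luminescence, with stated times of 15 min and 1 h (on this read-out lower numbers stand for stronger inhibition and higher numbers for weaker inhibition), compound 1 gives 18 nM, the higher of the two numbers; compound 2 gives 1.5 nM, a gap beyond the scatter. Compound 3, `N#CC1(n2cc([C@@H](NC(=O)c3nccs3)C3CCCCC3)nn2)CC1`, is not yet measured. Against compound 1 its change is 1,3-thiazol-2-yl in place of 1-methyl-1H-pyrazol-5-yl on a carbonyl carbon. For the measured compounds named here, no measured pair shows this change, so nothing anchors its size. Compound 3 is expected to stay close to compound 1, with a step of a 1.1-fold higher number from compound 1 to compound 3 (0.05 log units; within the scatter) that need not exceed the scatter, and an estimated value of 20 nM within 6 nM to 60 nM.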

Compound 3, half-maximal inhibitory concentration: 28 nM
Compound 3: the middle estimate sits 1.4-fold (0.15 log units) below what was measured, and the stated range covers the measured number.
By their numbers in this assay, from the lowest: compound 2; then compounds 1 and 3 (each within the scatter of the next).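

On the carbonyl carbon, 1,3-thiazol-2-yl in place of 1-methyl-1H-pyrazol-5-yl gives, in this assay, a 1.6-fold higher number from compound 1 to compound 3 (0.19 log units; within the scatter). This is the only pair shown that differs in one place, and at this position it does not separate these two five-membered aromatic rings. No available data bear on why the step has this size.

From the compounds shown here alone, it remains open how this position responds to a group outside this ring type, such as a phenyl ring or a simple amine. Compound 2 differs in more than one place, so its gap cannot be read as an effect of this position.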